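The source may hold more compounds than are shown below. What is called first, only, known or untested is meant among the compounds shown, and "the series" means these compounds.

In a functional assay on COLO 205 cells (Homo sapiens) for inhibition, read by MTT assay, with a stated time of 24 h (a lower number here means a stronger inhibitor, a higher number a weaker inhibitor), compound 1 `[O-]/[N+](=C\c1cn(-c2ccc(F)cc2)nn1)c1ccccc1` gives 10200 nM. Compound 2 `[O-]/[N+](=C\c1cn(CCC(F)(F)C(F)(F)C(F)(F)C(F)(F)C(F)(F)C(F)(F)C(F)(F)C(F)(F)F)nn1)c1ccccc1` reaches only the limit of this assay, > 100000 nM, which is a boundary of the measurement and not a number. Compound 3 `[O-]/[N+](=C\c1cn(CCC(F)(F)C(F)(F)C(F)(F)C(F)(F)C(F)(F)C(F)(F)F)nn1)Cc1ccccc1` likewise gives only the limit > 100000 nM in this assay, so its true value is not known. Compound 3 thus stands at the limit of > 100000 nM in this assay, at which 2 of the 3 values shown sit; of the three compounds shown only compound 1 has an actual number. Compound 4 `[O-]/[N+](=C\c1cn(CCC(F)(F)C(F)(F)C(F)(F)C(F)(F)C(F)(F)C(F)(F)C(F)(F)C(F)(F)F)nn1)Cc1ccccc1` differs from compound 3 by 1,1,2,2,2-pentafluoroethyl in place of fluoro on a saturated chain carbon bound to two fluorine atoms and a saturated chain carbon. No step between two measured compounds is shown, and with compound 3 already sitting at the limit the expected step is a number no higher from compound 3 to compound 4 (the limit leaves the size open), meaning no change beyond the usual scatter is expected. Compound 4 is therefore estimated at 100000 nM, with a range from 50000 nM to 300000 nM, and most likely it will again be reported only as a limit rather than a number.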

Compound 4, half-maximal inhibitory concentration: 9400 nM
Beside the measured number, compound 4's estimate is 11-fold (1.03 log units) above it; measured number below the stated range.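

In this assay, activity appears only when two changes come together. With benzyl on the double-bonded nitrogen, 1,1,2,2,2-pentafluoroethyl in place of fluoro on a saturated chain carbon bound to two fluorine atoms and a saturated chain carbon gives an at least 10-fold lower number from compound 3 to compound 4 (1.02 log units; beyond the scatter), so the length of the fluorinated chain matters at this place. With the long chain kept, benzyl in place of phenyl on that nitrogen gives an at least 10-fold lower number from compound 2 to compound 4 (1.02 log units; beyond the scatter), so the group on the nitrogen matters as well. Both sizes are only minimums because compound 2 and compound 3 have no true number: the limit of > 100000 nM in this assay, at which 2 of the 4 values shown sit.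

From the compounds shown here alone, it remains open whether a still longer fluorinated chain, or a chain ending in an amine or a carboxylic acid, would do better or worse at this place. These two pairs also cannot show whether benzyl in place of phenyl has a similar effect with other chains.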